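A few compounds are considered here, and "the series" means these few. Any claim that something is new, unique, unknown or untested is made for them only; others in the source may bear on it.

Four compounds form two pairs here. Compound 1 (`Nc1ncn(C[C@@H]2CO[C@H](CO)O2)c(=O)n1`) and compound 2 (`Nc1ncn(C[C@H]2CO[C@H](CO)O2)c(=O)n1`) share one core, while compound 3 (`Cc1nn(C[C@@H]2CO[C@H](CO)O2)c(=O)[nH]c1=O`) and compound 4 (`Cc1nn(C[C@H]2CO[C@H](CO)O2)c(=O)[nH]c1=O`) share another. In a functional assay on CCRF-CEM cells (Homo sapiens) (on this read-out higher numbers stand for an effect only at larger amounts of compound and lower numbers for an effect already at smaller amounts), compound 1 gives 20000 nM and compound 2 gives 30000 nM. In this assay compound 3 gives > 100000 nM, which is a limit of the assay and not a number.

Compound 4 has not been measured yet, and the change that leads to it is small: the two compounds have the same atoms and bonds and differ only in configuration as drawn: 1 of 2 stereo elements differ; a stereocentre at a saturated ring carbon is drawn R in compound 3 and S in compound 4. Nothing leaves and nothing enters, since a stereocentre at a saturated ring carbon is drawn R in compound 3 and S in compound 4.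

Within the data shown here, one measured step bears on this change: a 1.5-fold higher number from compound 1 to compound 2 (0.18 log units; within the scatter). It is relevant through (the fact that compounds 1 and 2 differ only in the configuration as drawn), although it is a single example on a different core. On that evidence, no step beyond the scatter is expected here. The expected step in this assay is a number no higher from compound 3 to compound 4 (the limit leaves the size open). With the limit of > 100000 nM in this assay, at which 1 of the 3 values shown sits, in mind, it is quite possible that the assay will again report only a limit. For compound 4 the estimated value is 100000 nM, with an expected range from 50000 nM to 200000 nM.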

Compound 4, half-maximal effective concentration: > 100000 nM
Compound 4: a limit, no number; the forecaster's own chance of this, stated with the estimate: 70%; the middle value sits exactly at the limit.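

In this assay, among these compounds, compound 3 and compound 4 both end at a limit of the assay and not at a number, so no step between them can be read. The compounds shown leave open where the true value of either compound lies, and whether the configuration at that saturated ring carbon matters at all on this core.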